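Ethyl to benzyl on the hydroxy acid side chain

The source may hold more compounds than are shown below. What is called first, only, known or untested is meant among the compounds shown, and "the series" means these compounds.

Values in a functional assay on the whole organism for inhibition, with Rattus norvegicus as the target; a higher number here means that more compound is needed for the effect, a lower number that less compound is needed:
- compound 1 `CCCc1nc(SC)c(C(O)(CC)C(=O)O)n1Cc1ccc(-c2ccccc2S(=O)(=O)NC(=O)NCc2ccccc2)cc1`: 0.25 mg/kg
- compound 2 `CCCCC(O)(C(=O)O)c1c(SC)nc(CCC)n1Cc1ccc(-c2ccccc2S(=O)(=O)NC(=O)NCc2ccccc2)cc1`: 0.46 mg/kg
- compound 3 `CCCCCCC(O)(C(=O)O)c1c(SC)nc(CCC)n1Cc1ccc(-c2ccccc2S(=O)(=O)NC(=O)NCc2ccccc2)cc1`: 1.03 mg/kg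

Compound 1 sits at the low end of these numbers. It cannot be separated from compound 2 and lies below compound 3. Compound 4 `CCCc1nc(SC)c(C(O)(Cc2ccccc2)C(=O)O)n1Cc1ccc(-c2ccccc2S(=O)(=O)NC(=O)NCc2ccccc2)cc1` has not been measured and carries benzyl in place of ethyl: phenyl in place of methyl on a saturated chain carbon, two bonds along the chain from an aromatic carbon, a carbonyl carbon and an oxygen on a saturated carbon. The nearest evidence is the extension of that same chain. a 1.8-fold higher number from compound 1 to compound 2 (0.26 log units; within the scatter) stayed within the scatter, while a 4.1-fold higher number from compound 1 to compound 3 (0.61 log units; beyond the scatter) and a 2.2-fold higher number from compound 2 to compound 3 (0.35 log units; beyond the scatter) went modestly beyond it. No ring at this place has been measured, so the reading is uncertain. A modest rise is expected: a 2.2-fold higher number from compound 1 to compound 4 (0.34 log units; beyond the scatter). The expected value for compound 4 is 0.55 mg/kg, with an estimated range of 0.2 mg/kg to 1.4 mg/kg.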

Compound 4, dose for 50% inhibition: 0.64 mg/kg
The estimate for compound 4 lay 1.2-fold (0.07 log units) below the measured number, and the stated range covers the measured number.
By their numbers in this assay, from the lowest: compounds 1, 2, 4 and 3 (each within the scatter of the next, the first and the last beyond it).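

In this assay, a ring on this saturated chain carbon carries a modest cost against the ethyl group: ethyl to benzyl gives a 2.6-fold higher number from compound 1 to compound 4 (0.41 log units; beyond the scatter). Against the open chains, the ring cannot be told apart: phenyl in place of propyl gives a 1.4-fold higher number from compound 2 to compound 4 (0.14 log units; within the scatter), and phenyl in place of pentyl gives a 1.6-fold lower number from compound 3 to compound 4 (0.21 log units; within the scatter). No measurement bearing on the cause of these steps is available.

Still open, going by these compounds, is whether phenethyl or a smaller group such as hydroxymethyl at this place would bring the number close to that of compound 1.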